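Naphthalen-1-yl in place of 3,5-dimethylphenyl on compound 1

The source may report more compounds than this note shows. Statements on the series, on what has been measured and on what is new or still open speak of the compounds shown alone.

For the measured compounds named here, in an ADME assay on MT4 cells (Homo sapiens) for cytotoxicity (a lower number here means that less compound is tolerated, a higher number that more compound is tolerated), compound 1 `Cc1cc(C)cc(Cn2c(=O)ccn(CC(=O)Nc3ccccc3Cl)c2=O)c1` gives 28500 nM, the lowest of the three numbers measured so far. Compound 2 `Cc1cc(C)cc(Cn2c(=O)ccn(CC(=O)Nc3cccc(Cl)c3)c2=O)c1` gives 167000 nM in this assay, and compound 3 `Cc1cc(C)cc(Cn2c(=O)ccn(CC(=O)Nc3cccc(C)c3C)c2=O)c1` gives 276000 nM. The measured steps, a 5.9-fold higher number from compound 1 to compound 2 (0.77 log units; beyond the scatter), a 9.7-fold higher number from compound 1 to compound 3 (0.99 log units; beyond the scatter) and a 1.7-fold higher number from compound 2 to compound 3 (0.22 log units; within the scatter), all change the aryl group on the amide-type nitrogen and leave the rest of the molecule untouched.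

Compound 4 `O=C(Cn1ccc(=O)n(Cc2cccc3ccccc23)c1=O)Nc1ccccc1Cl` departs from compound 1 at a different place: naphthalen-1-yl in place of 3,5-dimethylphenyl on a saturated chain carbon bound to an aromatic nitrogen. Going by the values given here, no measured step alters this part of the shared core, so the three steps above do not bear on the change directly; they show only that this assay does respond to changes of an aryl group elsewhere in the molecule by modest amounts. Without a guiding step, the expected step of a 1.1-fold lower number from compound 1 to compound 4 (0.06 log units; within the scatter) is set close to none beyond the scatter, with a wide margin. For compound 4 the estimate in this assay is therefore 25000 nM, expected to fall between 7000 nM and 90000 nM.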

Compound 4, half-maximal cytotoxic concentration: 207000 nM
The estimate for compound 4 lay 8.3-fold (0.92 log units) below the measured number; the measured number lies above the stated range.
By their numbers in this assay, from the lowest: compound 1; then compounds 2, 4 and 3 (each within the scatter of the next).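

In this assay, the group on a saturated chain carbon bound to an aromatic nitrogen proves able to shift the number: naphthalen-1-yl in place of 3,5-dimethylphenyl gives a 7.3-fold higher number from compound 1 to compound 4 (0.86 log units; beyond the scatter). The earlier steps shown here all changed the amide-type nitrogen, so they could not show that this second place also responds, here by a modest step beyond the scatter. Nothing available explains why this change has this effect.

On these data alone, it remains open whether the same change would raise the number with the 3-chlorophenyl of compound 2 or the 2,3-dimethylphenyl of compound 3 on the amide-type nitrogen. As far as these compounds go, how a plain phenyl or a pyridyl group would read at this place also remains open.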